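Amide variants of the benzyl ester series, thromboxane synthase

This account rests on a few compounds, and the source may have more. Where it says the series, first, only, none or still open, it means among the compounds named here.

Measured compounds:
compound 1, `COc1ccc(COCC(Cn2ccnc2)OCc2ccc(C(=O)OCc3ccccc3)cc2)cc1`: 1490 nM
compound 2, `CCCCCCCCOC(=O)c1ccc(COC(COCc2ccc(OC)cc2)Cn2ccnc2)cc1`: 21000 nM
compound 3, `CCNC(=O)c1ccc(COC(COCc2ccc(OC)cc2)Cn2ccnc2)cc1`: 12400 nM

The three measured compounds share one core and differ only in the group on the carbonyl carbon. In a functional assay for inhibition of Thromboxane-A synthase (Homo sapiens) (on this read-out higher numbers stand for weaker inhibition and lower numbers for stronger inhibition), compound 3 stands second highest of the three numbers, with compound 2 nearest (a 1.7-fold lower number from compound 2 to compound 3 (0.23 log units; within the scatter), within the scatter) and compound 1 furthest (an 8.3-fold higher number from compound 1 to compound 3 (0.92 log units; beyond the scatter)).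

Compound 4, `COc1ccc(COCC(Cn2ccnc2)OCc2ccc(C(=O)N(C)C)cc2)cc1`, is not yet measured. Its change from compound 3 is dimethylamino in place of ethylamino on a carbonyl carbon; the two have the same atoms, joined differently.

Among the compounds with values here, two measured steps touch the same carbonyl carbon. The step of an 8.3-fold higher number from compound 1 to compound 3 (0.92 log units; beyond the scatter) is modest and goes upward; the step of a 1.7-fold lower number from compound 2 to compound 3 (0.23 log units; within the scatter) stays within the scatter. Neither step swaps one amino group for another, so the present change is not directly covered. What the numbers show is that both groups other than benzyloxy give weak inhibition with little difference between them, which suggests the read-out is not sensitive to the group on the carbonyl carbon once benzyloxy is gone.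

Compound 4 is therefore expected to give about 14000 nM in this assay, within 5000 nM to 40000 nM, a step of a 1.1-fold higher number from compound 3 to compound 4 (0.05 log units; within the scatter) that is estimated to stay within the scatter.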

Compound 4, half-maximal inhibitory concentration: 1940 nM
Beside the measured number, compound 4's estimate is 7.2-fold (0.86 log units) above it, outside the stated range (below it).
By their numbers in this assay, from the lowest: compounds 1 and 4 (each within the scatter of the next); then compounds 3 and 2 (each within the scatter of the next).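

In this assay, the group on the carbonyl carbon still matters once benzyloxy is gone: dimethylamino and ethylamino, with the same atoms joined differently, are clearly separated (a 6.4-fold lower number from compound 3 to compound 4 (0.81 log units; beyond the scatter)). Weak inhibition therefore does not extend to every group other than benzyloxy, and dimethylamino also stands well clear of octyloxy (an 11-fold lower number from compound 2 to compound 4 (1.03 log units; beyond the scatter)). Dimethylamino and benzyloxy cannot be told apart in this read-out (a 1.3-fold higher number from compound 1 to compound 4 (0.11 log units; within the scatter)), and the change from ethylamino also takes away the one hydrogen-bond donor of the group, but nothing available bears on why the number moves.

As far as these compounds go, whether the loss of the amide hydrogen or the different joining of the same atoms goes with the stronger inhibition stays open, and methylamino, diethylamino or a plain unsubstituted amide on the same carbonyl carbon would help to separate the two readings. Also open, from the compounds shown here alone, is whether a cyclic amine such as pyrrolidine or morpholine in that place, or the free carboxylic acid, would stay with compound 4 or fall back towards compound 3.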